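This account rests on a few compounds, and the source may have more. Where it says the series, first, only, none or still open, it means among the compounds named here.

Working notes on the series in a functional assay on MCF7 cells (Homo sapiens) for cytotoxicity, read by MTT assay, with a stated time of 72 h; on this read-out lower numbers stand for higher toxicity in this test and higher numbers for lower toxicity in this test.

Of the compounds shown here, three have values so far. Among the compounds with values here, compound 1 `[SeH]c1nc([SeH])c2cccnc2n1` is the only one that returns a number: in this assay compound 1 gives 82700 nM. Compound 2 `CCCCCSc1nc(NCc2ccc([Se]C)cc2)c2ccccc2n1` does not reach a number. In this assay compound 2 gives > 100000 nM, which is a limit of the test. Compound 3 `[SeH]c1nc(NCc2ccccc2)c2ccccc2n1` behaves the same way. In this assay compound 3 gives > 100000 nM, again a limit. Compound 2 therefore stands at the limit of > 100000 nM in this assay, at which 2 of the 3 values shown sit, together with compound 3, while compound 1 alone lies below that ceiling. Within the data shown here, no two measured compounds differ in a single place, so no measured step is available to calibrate any single change.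

Compound 4 `CSc1nc(NCc2ccc([Se]C)cc2)c2ccccc2n1` is not yet measured in this assay. From compound 2 it differs by hydrogen in place of butyl on a saturated chain carbon bound to a sulfur. Because compound 2 rests at the limit of > 100000 nM in this assay, at which 2 of the 3 values shown sit, the expected step is none beyond the scatter, a step that the limit leaves unreadable from compound 2 to compound 4. Compound 4 is expected most likely to return a limit once more rather than a number. For compound 4 in this assay the estimate is 150000 nM, with a range from 60000 nM to 400000 nM.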

Compound 4, concentration lethal to 50% of the cells: > 100000 nM
Compound 4: only a limit was reported; the forecaster's own chance of this, stated with the estimate: 70%; the middle value is on the limit's open side.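

In this assay compound 4 gives > 100000 nM as a limit and not a number. Compound 2 also sits at a limit, so no step can be read between compound 2 and compound 4. The compounds shown leave open whether exchanging pentylsulfanyl for methylsulfanyl changes the read-out at all: the limit of > 100000 nM in this assay, at which 3 of the 4 values shown sit.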